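From Compound 2 to Its Isobutyl Counterpart

The source may report more compounds than this note shows. Statements on the series, on what has been measured and on what is new or still open speak of the compounds shown alone.

Of the compounds shown here, three built on a shared core have so far been measured in a functional assay on HCC827 cells (Homo sapiens) for inhibition, read by fluorescence, with a stated time of 72 h (a lower number here means a stronger inhibitor of growth, a higher number a weaker inhibitor of growth), and give a small set of numbers. Compound 1 (`CCCCCCn1cnc2c(Nc3ccc(Cl)cc3)nc(N[C@H]3CC[C@H](N)CC3)nc21`) gives 11700 nM there and compound 2 (`CC(C)=CCn1cnc2c(Nc3cccc(Cl)c3)nc(N[C@H]3CC[C@H](N)CC3)nc21`) gives 13500 nM so that the two sit within the scatter of each other. Compound 3 (`N[C@H]1CC[C@H](Nc2nc(Nc3ccc(O)cc3)c3ncn(C4CCCCC4)c3n2)CC1`) gives 32500 nM and is a weaker inhibitor of growth than compound 2 by a margin beyond the scatter. Compound 2 thus stands level with compound 1 and ahead of compound 3.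

Compound 4 (`CC(C)CCn1cnc2c(Nc3cccc(Cl)c3)nc(N[C@H]3CC[C@H](N)CC3)nc21`) has not yet been measured. It departs from compound 2 in one place, with isobutyl in place of 2-methylprop-1-en-1-yl on a saturated chain carbon bound to an aromatic nitrogen. Among the measured compounds shown here, no two measured compounds differ in only one place, so the data offer no direct guide to this change. Compound 1 at 11700 nM and compound 2 at 13500 nM differ in more than one place, their chains among them, yet remain within the scatter. Compound 3 at 32500 nM goes against that reading, so the expectation is a loose one. The expected step of a 1.0-fold lower number from compound 2 to compound 4 (0.02 log units; within the scatter) is none beyond the scatter in this assay and has no firm direction. Compound 4 is estimated at 13000 nM with an expected range from 6000 nM to 28000 nM for its growth inhibition.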

Compound 4, concentration for 50% growth inhibition: 10300 nM
Beside the measured number, compound 4's estimate is 1.3-fold (0.10 log units) above it; the measured number falls inside the stated range.
By their numbers in this assay, from the lowest: compounds 4, 1 and 2 (each within the scatter of the next); then compound 3.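

In this assay, among the compounds shown here, the exchange of 3-methylbut-2-en-1-yl for isopentyl gives a 1.3-fold lower number from compound 2 to compound 4 (0.12 log units; within the scatter), and this is the first comparison in the set between two compounds that differ in only one place. The two groups match in their counts of heavy atoms and carbon, and neither has a ring, so the pair isolates the one double bond outside aromatic rings; on a saturated chain carbon bound to an aromatic nitrogen, that double bond can be removed without a step beyond the scatter. No measurement on hand accounts for this result.

This remains a single pair, so it cannot be said whether the double bond would count for as little with the other groups that compound 1 and compound 3 carry elsewhere on the shared core. Every chain shown at this position is built of carbon alone, which leaves open how a hydroxyl group or a carboxylic acid on the chain, or a much shorter chain such as methyl, would read in this assay.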